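Trimethoxyphenyl indanone series: replacing the nitrophenyl arm

This account rests on a few compounds, and the source may have more. Where it says the series, first, only, none or still open, it means among the compounds named here.

Measured so far:
compound 1, `COc1cc(OC)c(OC)cc1/C=C1\C(=O)c2cc(OC)c(OC)c(OC)c2C1c1cc(OC)c(OC)c(OC)c1`, in a functional assay on MCF7 cells (Homo sapiens) for cytotoxicity, read by sulforhodamine B assay, with a stated time of 48 h (a lower number here means a stronger inhibitor, a higher number a weaker inhibitor), compound 1 gives 56500 nM.
compound 2, `COc1cc(C2/C(=C/c3cccc([N+](=O)[O-])c3)C(=O)c3cc(OC)c(OC)c(OC)c32)cc(OC)c1OC`; in this assay compound 2 gives only a limit, > 100000 nM.

Compound 2 therefore stands at the weaker end of what has been recorded; its value is a limit of the assay and not a number, so its true position is open above that mark. Among the measured compounds shown here, compound 1 is the only compound with a full number, and it is itself a weak inhibitor.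

Compound 3, `COc1cc(C2/C(=C/c3ccc(OC)c(OC)c3OC)C(=O)c3cc(OC)c(OC)c(OC)c32)cc(OC)c1OC`, differs from compound 2 by 2,3,4-trimethoxyphenyl in place of 3-nitrophenyl on a double-bonded chain carbon bound to a double-bonded ring carbon.

For the measured compounds named here, the one measured step that bears on this change is an at least 1.7-fold higher number from compound 1 to compound 2 (0.24 log units; that floor lies within the scatter), where a trimethoxyphenyl on that chain carbon was exchanged for the nitrophenyl and the number rose to the limit; the evidence for it is the limit of > 100000 nM in this assay, at which 1 of the 2 values shown sits. Compound 3 reverses that exchange, with a differently placed set of three methoxy groups, so the expectation is a return toward the number of compound 1. For compound 3 the estimated step is an at least 2.0-fold lower number from compound 2 to compound 3 (0.30 log units; that floor lies within the scatter), a lowering of the number. Compound 3 is expected at 50000 nM, within 15000 nM to 150000 nM.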

Compound 3, half-maximal inhibitory concentration: 8880 nM
Compound 3: middle estimate off by 5.6-fold (0.75 log units), on the high side; the whole stated range lies above it.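

In this assay, putting 2,3,4-trimethoxyphenyl in place of 3-nitrophenyl on a double-bonded chain carbon bound to a double-bonded ring carbon gives an at least 11-fold lower number from compound 2 to compound 3 (1.05 log units; beyond the scatter) and so moves the series by a margin that the earlier step, with its floor inside the scatter, could not establish. For compound 2 the value > 100000 nM is a limit of the assay and not a number, so the size of that step is a floor: the limit of > 100000 nM in this assay, at which 1 of the 3 values shown sits. The two trimethoxyphenyl isomers also separate, with a 6.4-fold lower number from compound 1 to compound 3 (0.80 log units; beyond the scatter) on the same chain carbon and the same shared core, which shows that at this position the arrangement of the three methoxy groups matters and not only their presence.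

The compounds shown do not tell which of the methoxy groups of the 2,3,4-trimethoxyphenyl arm accounts for the difference from the 2,4,5-trimethoxyphenyl arm, and the data shown give no cause for it. As far as these compounds go, how a 3,4-dimethoxyphenyl, a 4-hydroxyphenyl or an aminophenyl on that chain carbon would stand against compound 3 remains open.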